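The source may report more compounds than this note shows. Statements on the series, on what has been measured and on what is new or still open speak of the compounds shown alone.

- Compound 1 `O=C1CCCCC/C1=C\c1ccc(Cl)cc1`: 52600 nM
- Compound 2 `Cc1ccc(/C=C2\CCCCCC2=O)cc1`: > 500000 nM (a limit of the assay)
- Compound 3 `COc1ccc(/C=C2\CCCCCC2=O)cc1`: 250000 nM

In a functional assay on MOLT-4 cells (Homo sapiens) for inhibition (a lower number here means a stronger inhibitor, a higher number a weaker inhibitor), compound 3 gives 250000 nM, the higher of the two true numbers, and compound 1 gives 52600 nM. Compound 2 gives only a limit, > 500000 nM.

Compound 4 `CN(C)c1ccc(/C=C2\CCCCCC2=O)cc1` carries dimethylamino in place of methoxy on an aromatic carbon. Going by the values given here, no measured step makes this exact swap, so the guidance is indirect. Replacing chloro raised the number both times: a 4.8-fold higher number from compound 1 to compound 3 (0.68 log units; beyond the scatter) and an at least 9.5-fold higher number from compound 1 to compound 2 (0.97 log units; beyond the scatter). The remaining step, an at least 2.0-fold lower number from compound 2 to compound 3 (0.30 log units; that floor lies within the scatter), gives only a floor. Among the compounds with values here, compound 1, at 52600 nM, is thus the only compound with a clearly lower number, and dimethylamino does not restore its chloro group. Compound 4 is therefore expected to remain a weak inhibitor, close to compound 3 at 250000 nM.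

The expected change is a 1.1-fold higher number from compound 3 to compound 4 (0.05 log units; within the scatter), so no step beyond the scatter is expected. The estimated value for compound 4 is 280000 nM, with an expected range from 90000 nM to 700000 nM.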

Compound 4, half-maximal inhibitory concentration: 57400 nM
For compound 4 the middle estimate is 4.9-fold (0.69 log units) above the measured one; measured number below the stated range.
By their numbers in this assay, from the lowest: compounds 1 and 4 (each within the scatter of the next); then compound 3. At a limit, above all of these: compound 2.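

In this assay, going by these compounds alone, dimethylamino in place of methoxy gives a 4.4-fold lower number from compound 3 to compound 4 (0.64 log units; beyond the scatter), so chloro is no longer the only group at this aromatic carbon that gives a clearly lower number than methoxy. Dimethylamino in place of chloro gives a 1.1-fold higher number from compound 1 to compound 4 (0.04 log units; within the scatter), so the two groups cannot be told apart here, and a low number at this carbon is not tied to chloro alone. Dimethylamino in place of methyl, where the starting value is only a limit of the assay, gives an at least 8.7-fold lower number from compound 2 to compound 4 (0.94 log units; beyond the scatter).

On these data alone, it remains open whether a smaller amine, such as a plain amino group, or a ring amine such as morpholine, would match dimethylamino. As far as these compounds go, whether another halogen, such as fluoro or bromo, would match chloro also remains open.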